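Piperidin-1-yl in Place of Ethylsulfanyl on the Side Chain

The compounds below may be only part of what the source reports. "The series", "measured", "known", "first", "only" and "open" are said of these compounds alone.

Of the compounds shown here, three on one shared core have been measured in a functional assay on the whole organism with Rattus norvegicus as the target; on this read-out higher numbers stand for an effect only at larger amounts of compound and lower numbers for an effect already at smaller amounts. Compound 1 `N=c1sc2cc(OC(F)(F)F)ccc2n1CCS(=O)(=O)O` carries a sulfo group on its side chain; in this assay compound 1 gives > 10 mg/kg, which is a limit of the assay and not a number. Compound 2 `N=c1sc2cc(OC(F)(F)F)ccc2n1CCO` bears a hydroxy in that place and in this assay compound 2 gives 8 mg/kg. Compound 3 `CCSCCn1c(=N)sc2cc(OC(F)(F)F)ccc21`, with an ethylsulfanyl group, gives 2.2 mg/kg in this assay, the lowest of the two numbers shown. The steps leading to it read an at least 4.5-fold lower number from compound 1 to compound 3 (0.65 log units; beyond the scatter) and a 3.6-fold lower number from compound 2 to compound 3 (0.56 log units; beyond the scatter), while between the first two compounds the step is an at least 1.2-fold lower number from compound 1 to compound 2 (0.09 log units; that floor lies within the scatter).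

Compound 4 `N=c1sc2cc(OC(F)(F)F)ccc2n1CCN1CCCCC1` has not yet been measured. It differs from compound 3 by piperidin-1-yl in place of ethylsulfanyl on a saturated chain carbon, two bonds along the chain from an aromatic nitrogen. Among the measured compounds shown here, no measured step exchanges ethylsulfanyl for a ring; the two steps ending at compound 3 both put ethylsulfanyl in place of sulfo or hydroxy and lower the number, and the new change leaves the count of acceptors unchanged while adding a six-membered ring. The expectation is therefore a step of modest size at most, toward a somewhat higher number, namely a 1.6-fold higher number from compound 3 to compound 4 (0.20 log units; within the scatter). Compound 4 is thus estimated to give 3.5 mg/kg in this assay, with a range from 1.2 mg/kg to 10 mg/kg.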

Compound 4, dose for half-maximal effect: 2 mg/kg
Estimate against measurement, compound 4: 1.8-fold (0.24 log units) above, within the range that was stated.
By their numbers in this assay, from the lowest: compounds 4 and 3 (each within the scatter of the next); then compound 2. At a limit, above all of these: compound 1.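

In this assay, piperidin-1-yl in place of ethylsulfanyl on a saturated chain carbon, two bonds along the chain from an aromatic nitrogen, gives a 1.1-fold lower number from compound 3 to compound 4 (0.04 log units; within the scatter). Among the compounds shown here, this place therefore holds a six-membered non-aromatic ring with no change beyond the scatter, something the earlier compounds, none of which has a ring in the side chain, could not show. Piperidin-1-yl also matches ethylsulfanyl in standing apart from hydroxy, with a 4.0-fold lower number from compound 2 to compound 4 (0.60 log units; beyond the scatter), while against sulfo the step reads an at least 5.0-fold lower number from compound 1 to compound 4 (0.69 log units; beyond the scatter), a floor and not a measured size: the limit of > 10 mg/kg in this assay, at which 1 of the 4 values shown sits.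

Whether the ring nitrogen of piperidin-1-yl matters at this place stays open, as the compounds shown include neither a cyclohexyl nor a morpholin-4-yl group on the side chain, and no diethylamino group or longer chain appears there. Nor can they tell whether the match between piperidin-1-yl and ethylsulfanyl carries over to a core without the trifluoromethoxy group.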